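The source may hold more compounds than are shown below. What is called first, only, known or untested is meant among the compounds shown, and "the series" means these compounds.

Of the compounds shown here, three have so far been measured in an ADME assay (liver) for metabolic stability, with Liver microsome (Rattus norvegicus) as the target, read by LC-MS, using microsomes, with a stated time of 30 min, tested at 4 uM; a lower number here means that less of the compound is left, a higher number that more of the compound is left. Compound 1 `COCCn1c(-c2ccccc2Cl)nc2c(N3CCN4C(=O)CCC4C3)nc(C)nc21` gives 91%, compound 2 `CC(=O)NCCn1c(-c2ccccc2Cl)nc2c(N3CCN(C)CC3)nc(C)nc21` gives 0%, and compound 3 `Cc1nc(N2CCN(C)CC2)c2nc(-c3ccccc3C(F)(F)F)n(C3CCOCC3)c2n1` gives 38%. Compound 3 is therefore the second highest of the three, and its gaps to both neighbours lie beyond the scatter: compound 2 is the nearest, and compound 1 is further away.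

Compound 4 `Cc1nc(N2CCN(C)CC2)c2nc(-c3ccccc3C3CC3)n(C3CCOCC3)c2n1` differs from compound 3 in one group: cyclopropyl in place of trifluoromethyl on an aromatic carbon. In words, cyclopropyl takes the place of trifluoromethyl on an aromatic carbon, ortho to a large group, turning the 2-(trifluoromethyl)phenyl into a 2-cyclopropylphenyl.

For the measured compounds named here, no two measured compounds differ in only one place, so the data offer no direct precedent for this change. The three measured compounds differ in several places at once, and their wide spread cannot be assigned to any single group. The expectation therefore starts from compound 3 at 38% and rests on a judgement about the structural change alone, which leaves it uncertain. The expected step of a number 13 percentage points lower from compound 3 to compound 4 (beyond the scatter) is downward and of moderate size. For compound 4 the estimate is 25%, with an expected range from 5% to 50%.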

Compound 4, percent of the compound remaining: 67%
The estimate for compound 4 lay 42 percentage points below the measured number; measured number above the stated range.
By their numbers in this assay, from the lowest: compound 2; then compound 3; then compound 4; then compound 1.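

For the compounds shown here, this pair is the first here that differs in only one place, so this assay can now be read for a single change on an aromatic carbon, ortho to a large group: cyclopropyl in place of trifluoromethyl gives a number 29 percentage points higher from compound 3 to compound 4 (beyond the scatter). Going by these compounds alone, with the rest of the structure unchanged, the move from 2-(trifluoromethyl)phenyl to 2-cyclopropylphenyl, which removes all the fluorine and brings in a three-membered ring of carbon only, shows that this one place alone can shift the read-out by more than the usual scatter, something the earlier compounds, which differ in several places at once, could not show. Nothing in the data shown explains why more of the compound is left after this change.

As far as these compounds go, only one replacement at this place can be read, so it remains open how a nitrile, a methoxy group or a longer alkyl chain would behave there. A single pair also cannot tell whether the same change would give a step in the same direction on a different remainder of the molecule, such as the other side chains seen in the set.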